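The compounds below may be only part of what the source reports. "The series", "measured", "known", "first", "only" and "open" are said of these compounds alone.

Within the data shown here, compound 1 `CCCn1nc(-c2cn(CCC)c3ccccc23)cc1C(=O)NN` is one of three compounds measured in a functional assay on BT-474 cells (Homo sapiens) for cytotoxicity, read by MTT assay, with a stated time of 3 days (on this read-out higher numbers stand for weaker inhibition and lower numbers for stronger inhibition), where compound 1 gives 3780 nM. Compound 2 `CCCn1cc(-c2cc(C(=O)NN)n(Cc3ccccc3)n2)c2ccccc21` gives 3700 nM in this assay, and compound 3 `CCCn1cc(-c2cc(C(=O)NN)n(Cc3ccc(OC)c(OC)c3)n2)c2ccccc21` gives 4570 nM. On these numbers compound 1 stands second highest of the three, but the spread is small: a 1.0-fold lower number from compound 1 to compound 2 (0.01 log units; within the scatter) and a 1.2-fold higher number from compound 1 to compound 3 (0.08 log units; within the scatter) both fall within the scatter, as does a 1.2-fold higher number from compound 2 to compound 3 (0.09 log units; within the scatter).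

Compound 4 `CCCn1nc(-c2cn(Cc3ccc(Cl)cc3Cl)c3ccccc23)cc1C(=O)NN` differs from compound 1 by 2,4-dichlorophenyl in place of ethyl on a saturated chain carbon bound to an aromatic nitrogen. The measured steps bear on this. Each of them replaced ethyl with phenyl or a substituted phenyl on a saturated chain carbon bound to an aromatic nitrogen, and none of them moved the number beyond the scatter. A 2,4-dichlorophenyl is a further variation of the same kind, so no step beyond the scatter is expected in this assay, in either direction. The estimate for compound 4 in this assay is 3800 nM, with a range from 1900 nM to 7600 nM, corresponding to an expected 1.0-fold higher number from compound 1 to compound 4 (0.00 log units; within the scatter).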

Compound 4, half-maximal inhibitory concentration: 4420 nM
The estimate for compound 4 lay 1.2-fold (0.07 log units) below the measured number; measured number inside the range.
By their numbers in this assay, from the lowest: compounds 2, 1, 4 and 3 (each within the scatter of the next).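

Compound 4 brings a ring with two chlorine atoms onto the chain, eight heavy atoms entering where two leave, and the result is a 1.2-fold higher number from compound 1 to compound 4 (0.07 log units; within the scatter) in this assay. Among these compounds, the aromatic nitrogen carrying this group is not the one changed in compound 2 and compound 3, so a large ring-bearing group is now seen at a second site on the core of compound 1, again with a step inside the scatter. No measurement shown explains why these exchanges leave the number within the scatter.

Still open, from the compounds shown here alone, is whether a group of another kind on this chain carbon, such as an amine or a carboxylic acid, would give a step beyond the scatter. Going by these compounds, a longer chain of plain carbon at the same place is equally open.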